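The source may report more compounds than this note shows. Statements on the series, on what has been measured and on what is new or still open speak of the compounds shown alone.

Measured so far in an assay for inhibition of Indoleamine 2,3-dioxygenase 1 (Homo sapiens), with a stated time of 1 h, tested at 10 uM; on this read-out higher numbers stand for more inhibition at the one concentration tested (going by the name of the read-out) and lower numbers for less inhibition:
- compound 1 `Nc1cccc(CNc2cc(Br)cc3[nH]ncc23)c1`: 31%
- compound 2 `ONc1cccc(CNc2cc(Br)cc3[nH]ncc23)c1`: 53%

Compound 1 stands lowest of the two numbers in this assay. Its nearest neighbour is compound 2, whose change is hydroxy in place of hydrogen on a nitrogen on an aromatic ring, and the step runs a number 22 percentage points higher from compound 1 to compound 2 (beyond the scatter), beyond the scatter, a modest gain.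

Compound 3 `Nc1cc(CNc2cc(Br)cc3[nH]ncc23)ccc1O` is not yet measured. Relative to compound 1 the change is hydroxy in place of hydrogen on an aromatic carbon. Going by the values given here, the hydroxy here enters on an aromatic carbon, ortho to an amino group and para to a large group, so this is not the same change as in compound 2; the only measured step, a number 22 percentage points higher from compound 1 to compound 2 (beyond the scatter), bears on it loosely, as the sole example of adding a hydroxy to the aniline part of the shared core.

On that single precedent a small rise in this assay is expected for compound 3, a number 11 percentage points higher from compound 1 to compound 3 (beyond the scatter), though a result within the scatter of compound 1 would not surprise. The estimate for compound 3 is 42%, with a range of 25% to 62%.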

Compound 3, a percentage reported as inhibition, at one concentration (the size of the read-out at that concentration, not a potency): 32%
Compound 3: middle estimate off by 10 percentage points, on the high side; the measured number falls inside the stated range.
By their numbers in this assay, from the lowest: compounds 1 and 3 (each within the scatter of the next); then compound 2.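

In this assay, hydroxy in place of hydrogen on an aromatic carbon, ortho to an amino group and para to a large group, gives a number 1 percentage points higher from compound 1 to compound 3 (within the scatter), so at this position the change does not move the read-out beyond the scatter. Going by these compounds alone, the only other step from compound 1, a number 22 percentage points higher from compound 1 to compound 2 (beyond the scatter), puts the hydroxy on the nitrogen and lies beyond the scatter, which shows that adding a hydroxy to this ring does not give a rise wherever it enters. Nothing on hand explains why the two placements give different outcomes.

The compounds shown leave open whether the rise seen with compound 2 is specific to hydroxy on that nitrogen or would also appear with a methoxy group there. They also leave open whether a methoxy group or a fluorine atom on the aromatic carbon that carries the hydroxy in compound 3 would likewise stay within the scatter of compound 1, and whether the two hydroxy placements would combine in one compound.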